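Compound 4: a methoxy added to compound 2

The source may report more compounds than this note shows. Statements on the series, on what has been measured and on what is new or still open speak of the compounds shown alone.

In a functional assay on HeLa cells (Homo sapiens) for inhibition, read by MTT assay, with a stated time of 48 h (a higher number here means a weaker inhibitor of growth, a lower number a stronger inhibitor of growth), compound 1 (`Cn1cc(C2CC(c3ccccc3)=NN2C(=O)c2ccc(Cl)nc2)c2ccccc21`) reads 8310 nM and compound 3 (`Cn1cc(C2CC(c3ccccc3)=NN2C(=O)c2ccncc2)c2ccccc21`) reads 590 nM while compound 2 (`COc1ccc(C(=O)N2N=C(c3ccccc3)CC2c2cn(C)c3ccccc23)cn1`) reads 3980 nM in the middle of the three. The change from compound 2 to compound 4 (`COc1ccc2c(c1)c(C1CC(c3ccccc3)=NN1C(=O)c1ccc(OC)nc1)cn2C`) is methoxy in place of hydrogen on an aromatic carbon and nothing else. The measured steps all lie in the group on the carbonyl: a 2.1-fold lower number from compound 1 to compound 2 (0.32 log units; beyond the scatter) and a 6.7-fold lower number from compound 2 to compound 3 (0.83 log units; beyond the scatter) are modest and a 14-fold lower number from compound 1 to compound 3 (1.15 log units; beyond the scatter) is large. None touches the core, so they show how far the series can move but give no direction here. No step beyond the scatter is expected in this assay from this change. The estimated step is a 1.3-fold lower number from compound 2 to compound 4 (0.12 log units; within the scatter) with real uncertainty either way. For compound 4 the estimate is 3000 nM with 900 nM to 10000 nM as the expected range.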

Compound 4, concentration for 50% growth inhibition: 1100 nM
The estimate for compound 4 lay 2.7-fold (0.44 log units) above the measured number, within the range that was stated.
By their numbers in this assay, from the lowest: compounds 3 and 4 (each within the scatter of the next); then compound 2; then compound 1.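

In this assay, methoxy in place of hydrogen on the six-membered aromatic ring of carbon only gives a 3.6-fold lower number from compound 2 to compound 4 (0.56 log units; beyond the scatter). Among these compounds, this is the first measured step outside the group on the carbonyl, and it shows that the number also responds to a change on the shared core. Nothing at hand gives a reason for this step.

From the compounds shown here alone, whether another group at this position, such as a hydroxyl or an amine, would give a similar step remains open. Also open, going by these compounds, is whether the same methoxy would lower the number with the pyridin-4-yl of compound 3 on the carbonyl.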